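Benzyl for Methyl on Two Related Cores

A few compounds are considered here, and "the series" means these few. Any claim that something is new, unique, unknown or untested is made for them only; others in the source may bear on it.

Compound 1 `COc1ccc(Cn2cc3cc(C(=N)Nc4cccc(C(F)(F)F)c4)ncc3n2)cc1` carries a 4-methoxybenzyl group on its core, whereas compound 2 `Cn1cc2cc(C(=N)Nc3cccc(C(F)(F)F)c3)ncc2n1` carries only a methyl at that place. In a functional assay on MDA-MB-231 cells (Homo sapiens) for cytotoxicity, read by MTT assay, with a stated time of 72 h (a higher number here means a weaker inhibitor, a lower number a stronger inhibitor), compound 1 gives 15500 nM. For compound 2 the read-out in this assay reaches only the limit of the assay, > 50000 nM. The step between them is an at least 3.2-fold lower number from compound 2 to compound 1 (0.50 log units; beyond the scatter), and the change it describes is 4-methoxyphenyl in place of hydrogen on a saturated chain carbon bound to an aromatic nitrogen. Compound 3 `Cn1ncc2cc(C(=N)Nc3cccc(C(F)(F)F)c3)ncc21` is built from the same atoms as compound 2 joined differently; how the two cores differ is not broken down here. In this assay compound 3 likewise gives only the limit of the assay, > 50000 nM. Compound 4 `COc1ccc(Cn2ncc3cc(C(=N)Nc4cccc(C(F)(F)F)c4)ncc32)cc1` stands to compound 3 exactly as compound 1 stands to compound 2: 4-methoxyphenyl in place of hydrogen on a saturated chain carbon bound to an aromatic nitrogen. Since the place is the same in both pairs, this is the same change, not merely the same kind. Going by the values given here, two of the three values measured so far sit at the limit of > 50000 nM in this assay, at which 2 of the 3 values shown sit. Compound 4 is expected to show an at least 2.7-fold lower number from compound 3 to compound 4 (0.44 log units; beyond the scatter), an expectation that rests on an at least 3.2-fold lower number from compound 2 to compound 1 (0.50 log units; beyond the scatter). Compound 4 is accordingly estimated at 18000 nM, within a range from 7000 nM to 50000 nM.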

Compound 4, half-maximal inhibitory concentration: 29800 nM
Beside the measured number, compound 4's estimate is 1.7-fold (0.22 log units) below it; measured number inside the range.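

In this assay, the change from methyl to 4-methoxybenzyl on the core of compound 3 gives an at least 1.6-fold lower number from compound 3 to compound 4 (0.22 log units; that floor lies within the scatter), so this pair does not go against the direction seen on the core of compound 2, but its floor alone does not establish a real gain. Set side by side, the two steps read: the same change on two cores in this assay, an at least 3.2-fold lower number (0.50 log units; beyond the scatter) from compound 2 to compound 1 and an at least 1.6-fold lower number (0.22 log units; that floor lies within the scatter) from compound 3 to compound 4; the limit leaves it open whether they differ Compound 2 and compound 3 each stand at a limit of the assay rather than at a number, so the true size of each step remains unknown and the data do not show that the change carries over with the same size on both cores: the limit of > 50000 nM in this assay, at which 2 of the 4 values shown sit.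

The compounds shown leave open whether the methoxy group contributes to these steps, as they do not include a plain benzyl or a longer chain such as butyl at this place. They also leave open whether the change would carry over if an amine or a carboxylic acid stood in place of the trifluoromethyl group.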